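This account rests on a few compounds, and the source may have more. Where it says the series, first, only, none or still open, it means among the compounds named here.

Three compounds share one core and differ only at the outer end of the molecule, in the side of the ring that carries the long chain, or in the charged ring at the far end of that chain. Compound 1 is `Cc1cc(-n2cc(C(=O)Nc3cc(F)cc(F)c3)c(=O)c3ccc(N(C)C)nc32)ccc1OCCCCCCC[N+]1(C)CCCC1`. Compound 2 is `CN(C)c1ccc2c(=O)c(C(=O)Nc3cc(F)cc(F)c3)cn(-c3ccc(OCCCCCCC[N+]4(C)CCCC4)c(Cl)c3)c2n1`. Compound 3 is `Cc1cc(-n2cc(C(=O)Nc3cc(F)cc(F)c3)c(=O)c3ccc(N(C)C)nc32)ccc1OCCCCCCC[N+]1(C)CCN(C)CC1`. In an assay on LX2 cells for inhibition of COL1A1 promoter (Homo sapiens), read by a luciferase reporter, with a stated time of 24 h, tested at 50 uM (on this read-out higher numbers stand for a stronger effect at the one concentration tested and lower numbers for a weaker effect), compound 1 gives 35.9%, compound 2 gives 2.59% and compound 3 gives 32%.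

The move from compound 1 to compound 2 is chloro in place of methyl on an aromatic carbon and produced a number 33.3 percentage points lower from compound 1 to compound 2 (beyond the scatter). The move from compound 1 to compound 3 is a group of 8 heavy atoms (6 carbon, 2 nitrogen; one six-membered non-aromatic ring with 2 hetero atoms) in place of a group of 6 heavy atoms (5 carbon, 1 nitrogen; one five-membered non-aromatic ring with 1 hetero atom), on a saturated chain carbon, seven bonds along the chain from an oxygen on an aromatic ring and produced only a number 3.9 percentage points lower from compound 1 to compound 3 (within the scatter), so compound 1 and compound 3 cannot be told apart on this read-out.

Compound 4 is `CN1CC[N+](C)(CCCCCCCOc2ccc(-n3cc(C(=O)Nc4cc(F)cc(F)c4)c(=O)c4ccc(N(C)C)nc43)cc2Cl)CC1`. It stands to compound 3 as compound 2 stands to compound 1: the change is chloro in place of methyl on an aromatic carbon, and the place around it is described in the same words as before, so this is the same change made on a core that differs from that of compound 1 only by the charged ring at the end of the chain. Because compound 3 gave 32%, and because the same change once produced a number 33.3 percentage points lower from compound 1 to compound 2 (beyond the scatter), compound 4 is expected to give 4%, somewhere between 0% and 16%. That expectation amounts to an estimated step of a number 28 percentage points lower from compound 3 to compound 4 (beyond the scatter) in this assay. Whether the large drop repeats on this second core, or whether it was tied to the ring present in compound 1 and compound 2 alone, is what the measurement of compound 4 will show.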

Compound 4, a percentage reported as inhibition, at one concentration (the size of the read-out at that concentration, not a potency): 15.4%
Beside the measured number, compound 4's estimate is 11.4 percentage points below it, and the stated range covers the measured number.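

In this assay, chloro in place of methyl again lowers the number, with a number 16.6 percentage points lower from compound 3 to compound 4 (beyond the scatter), so the direction of the change carries over to the second core, but its size does not: the same change on two cores in this assay, a number 33.3 percentage points lower (beyond the scatter) from compound 1 to compound 2 and a number 16.6 percentage points lower (beyond the scatter) from compound 3 to compound 4, 16.7 percentage points apart, beyond the scatter of two such steps

The same result appears when the pairs are read the other way, as the swap of the charged ring at the end of the chain gives a number 12.8 percentage points higher from compound 2 to compound 4 (beyond the scatter) with chloro on the aromatic ring, unlike the small step seen with methyl there: the same change on two cores in this assay, a number 3.9 percentage points lower (within the scatter) from compound 1 to compound 3 and a number 12.8 percentage points higher (beyond the scatter) from compound 2 to compound 4, 16.7 percentage points apart, beyond the scatter of two such steps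

This shows that the effect of the chloro change depends on which charged ring the molecule carries, but two pairs of compounds at a single concentration do not establish a rule for the series, and they do not show why the size of the step differs.

On these data alone, it remains open whether a fluoro or a methoxy group in place of the methyl would lower the number as chloro does, and whether the size of such a step would again depend on the charged ring. A shorter chain between the oxygen and the charged ring is also untested within these compounds, so the same dependence cannot be assumed to hold there.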